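A few compounds are considered here, and "the series" means these few. Any claim that something is new, unique, unknown or untested is made for them only; others in the source may bear on it.

Compound 1 `FC(F)(F)c1ccc2[nH]c(-c3cn(-c4ccccc4)nc3-c3ccc(Cl)cc3)nc2c1`: 3360 nM
Compound 2 `COc1ccc(-c2nn(-c3ccccc3)cc2-c2nc3cc(Br)ccc3[nH]2)cc1`: 6370 nM

In a functional assay on A549 cells (Homo sapiens) for antiproliferative activity, read by MTT assay, with a stated time of 48 h (on this read-out lower numbers stand for stronger inhibition and higher numbers for weaker inhibition), compound 2 gives 6370 nM and compound 1 gives 3360 nM. For the measured compounds named here, these two values lie within the scatter of each other, so the numbers do not separate compound 2 from the only other compound measured.

Compound 3 `COc1ccc(-c2nn(-c3ccccc3)cc2-c2nc3cc(C(F)(F)F)ccc3[nH]2)cc1` differs from compound 2 in one place: trifluoromethyl stands in place of bromo on an aromatic carbon of a six-membered aromatic ring of carbon only, part of a fused or bridged system of two rings (trifluoromethyl in place of bromo on an aromatic carbon). Going by the values given here, no measured pair here isolates a single change, so the data do not show what this replacement does in this assay. Among the compounds with values here, the only guide is the narrow spread of the two values already in hand, and no shift beyond the scatter is expected in either direction.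

The estimated change is a 1.4-fold lower number from compound 2 to compound 3 (0.15 log units; within the scatter), which is expected to stay within the scatter. For compound 3 the expected value is 4500 nM, with an estimated range from 1500 nM to 13000 nM.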

Compound 3, half-maximal inhibitory concentration: 4820 nM
Estimate against measurement, compound 3: 1.1-fold (0.03 log units) below; the measured number falls inside the stated range.
By their numbers in this assay, from the lowest: compounds 1, 3 and 2 (each within the scatter of the next).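

In this assay, for the compounds shown here, trifluoromethyl in place of bromo gives a 1.3-fold lower number from compound 2 to compound 3 (0.12 log units; within the scatter), and this is the first pair in which a change at this aromatic carbon stands alone. Bromo with 1 heavy atom and trifluoromethyl with 4 heavy atoms therefore cannot be told apart here, so at this position the read-out does not separate the two groups. Compound 3 also forms a single-change pair with compound 1, where methoxy in place of chloro on an aromatic carbon gives a 1.4-fold higher number from compound 1 to compound 3 (0.16 log units; within the scatter), so this second site shows no separation either, and no independent measurement is available to explain either result.

On these data alone, what remains open is whether any group at these two places can move the number beyond the scatter, for example an amine or a carboxylic acid at the carbon that carries bromo or trifluoromethyl, or a hydroxyl group at the carbon that carries chloro or methoxy. The three compounds also leave open whether these small differences would hold in cell lines other than the one tested, or whether the shared core sets the level of the read-out.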